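The source may report more compounds than this note shows. Statements on the series, on what has been measured and on what is new or still open speak of the compounds shown alone.

Measured compounds:
- compound 1, `CC1OC(n2c(=O)n(C)c3c(O)nc(N)nc32)[C@H](O)[C@@H]1O`: 0%
- compound 2, `C=CCn1c(=O)n([C@@H]2O[C@H](CO)[C@H]3OC(=O)O[C@H]32)c2nc(N)nc(O)c21`: 50%
- compound 3, `C=CCn1c(=O)n(C2C=CC(CO)O2)c2nc(N)nc(O)c21`: 45%

The three compounds share a core and were run in a functional assay on the whole organism (B cells) with Mus musculus as the target; a lower number here means a smaller maximal response, a higher number a larger maximal response. Compound 1 gives the lowest number of the three, 0%. Compound 3 stands nearest to it at 45%, a gap beyond the usual scatter, and compound 2 stands furthest at 50%, also beyond the scatter. Among the compounds with values here, compound 2 and compound 3 differ from compound 1 in more than one place, so no single step between them is counted.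

The unmeasured compound 4, `Cn1c(=O)n(C2OC(CO)[C@@H](O)[C@H]2O)c2nc(N)nc(O)c21`, differs from compound 1 in one place: hydroxy in place of hydrogen on a saturated chain carbon bound to a saturated ring carbon. Whether this one change alone moves the maximal response is not shown by any measured pair. An upward step is nonetheless expected, with wide uncertainty, because compound 2 gives 50% and compound 3 gives 45% while both carry a hydroxymethyl where compound 1 carries a methyl. The expected step is a number 20 percentage points higher from compound 1 to compound 4 (beyond the scatter). Compound 4 is therefore estimated at 20%, in a range from 0% to 50%.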

Compound 4, largest response reached (reported as maximal response), in percent of the reference or control that the assay uses: 99%
Compound 4: the middle estimate sits 79 percentage points below what was measured; measured number above the stated range.
By their numbers in this assay, from the lowest: compound 1; then compounds 3 and 2 (each within the scatter of the next); then compound 4.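

At this position, on a saturated chain carbon bound to a saturated ring carbon, replacing hydrogen with hydroxy, which turns methyl into hydroxymethyl, gives in this assay a step of a number 99 percentage points higher from compound 1 to compound 4 (beyond the scatter). The earlier compounds shown here could not show this, as none of them formed a pair differing in only one place, whereas here the whole step belongs to this single change. Nothing available explains why one hydroxy has so large an effect.

The compounds shown leave open whether hydroxy is specifically needed here, or whether a group such as aminomethyl, methoxymethyl or a carboxylic acid at this place would also raise the number. On these data alone, compound 2 and compound 3 also carry hydroxymethyl, but they differ from compound 4 in more than one place, so how this change acts in their setting remains open.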